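A few compounds are considered here, and "the series" means these few. Any claim that something is new, unique, unknown or untested is made for them only; others in the source may bear on it.

In an assay on membranes from Chem-1 cells for displacement of a labelled ligand from prostaglandin E2 receptor EP3 subtype (Homo sapiens), read by scintillation counting, with a stated time of 2 h (on this read-out lower numbers stand for stronger inhibition and higher numbers for weaker inhibition), the three measured compounds gave:

compound 1, `CCC(/C=C1\OC(=O)NC1=O)(CC)c1ccc(-c2ccc3cccc(F)c3c2)[nH]c1=O`: 13 nM
compound 2, `CCC(CC)C(/C=C1\OC(=O)NC1=O)c1ccc(-c2ccc3cccc(F)c3c2)[nH]c1=O`: 13 nM
compound 3, `CCC(/C=C1\OC(=O)NC1=O)(CC)c1ccc(-c2ccc3cc(F)cc(F)c3c2)[nH]c1=O`: 28 nM

Compound 2 is level with compound 1, and together they hold the lowest number of the three. Within the data shown here, the only measured single change is a 2.2-fold higher number from compound 1 to compound 3 (0.33 log units; beyond the scatter), which concerns a fluoro on an aromatic ring.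

Compound 4, `O=C1NC(=O)/C(=C/C(c2ccc(-c3ccc4cccc(F)c4c3)[nH]c2=O)C2CC2)O1`, differs from compound 2 by cyclopropyl in place of pentan-3-yl on a saturated chain carbon bound to an aromatic carbon and a double-bonded chain carbon. Among the measured compounds shown here, no measured step touches this chain carbon, so the fluoro step does not bear on the change. Compound 1 and compound 2 show that two arrangements of the same five carbons here give the same number. With no direct guide, a small rise is expected, a 1.9-fold higher number from compound 2 to compound 4 (0.28 log units; within the scatter), and the uncertainty is wide. Compound 4 is estimated at 25 nM, with a range from 8 nM to 80 nM.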

Compound 4, inhibition constant: 22 nM
For compound 4 the middle estimate is 1.1-fold (0.06 log units) above the measured one; the measured number falls inside the stated range.
By their numbers in this assay, from the lowest: compounds 1, 2, 4 and 3 (each within the scatter of the next, the first and the last beyond it).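

In this assay, cyclopropyl in place of pentan-3-yl gives a 1.7-fold higher number from compound 2 to compound 4 (0.23 log units; within the scatter). So this chain carbon accepts a group with fewer carbons that is also a ring, not only the two arrangements of five carbons seen earlier, with no step beyond the scatter. No measurement shown here explains this result.

Still open, as far as these compounds go, is whether an amine, a carboxylic acid or a longer chain on this carbon would leave the number as little changed. From the compounds shown here alone, it is also open whether cyclopropyl would give the same result alongside the extra fluoro of compound 3.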